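Stripping the alkynyl chain from a weakly active fused core

The source may hold more compounds than are shown below. What is called first, only, known or untested is meant among the compounds shown, and "the series" means these compounds.

This study follows three compounds built on a shared bicyclic core carrying a triazolylmethyl group, tested in a functional assay on A549 cells (Homo sapiens) for antiproliferative activity, read by MTT assay, with a stated time of 72 h; on this read-out higher numbers stand for weaker inhibition and lower numbers for stronger inhibition. Compound 1 `CCCCCCC#Cc1c(CCCCCC)oc2nc(=O)n(Cc3cn(-c4ccc(Cl)cc4)nn3)cc12` gives a value that is only a limit of the assay, > 100000 nM. Compound 2 `O=c1nc2oc(CCCCl)c(C#CCCCCl)c2cn1Cc1cn(-c2ccc(Cl)cc2)nn1` likewise gives only a limit in this assay, > 100000 nM. Compound 3 `CCCCCc1ccc(C#Cc2c(-c3ccc(CCCCC)cc3)oc3nc(=O)n(Cc4cn(-c5ccccc5F)nn4)cc23)cc1`, which carries aryl groups in place of the alkyl chains, gives 38700 nM in this assay. Compound 2 therefore stands at the limit of this assay, and so does one of the two other values shown, as noted in the limit of > 100000 nM in this assay, at which 2 of the 3 values shown sit; only compound 3 returns a measured number.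

The step from compound 2 to compound 4 `O=c1nc2oc(CCCCl)cc2cn1Cc1cn(-c2ccc(Cl)cc2)nn1` is a simple removal: hydrogen in place of 5-chloropent-1-yn-1-yl on an aromatic carbon. Going by the values given here, no step between measured compounds is known, so the size of this change can only be expected, not read from the data. Given that compound 2 itself returns only a limit, > 100000 nM, the author expects that compound 4 shows no gain in this assay, and a step that the limit leaves unreadable from compound 2 to compound 4 that lies within the scatter or toward weaker inhibition. The estimate for compound 4 is 150000 nM, with a range from 50000 nM to 500000 nM, most likely reported again as a limit.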

Compound 4, half-maximal inhibitory concentration: 52000 nM
Compound 4: the middle estimate sits 2.9-fold (0.46 log units) above what was measured, within the range that was stated.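

In this assay, compound 4 gives a measured number, 52000 nM, so the shared core keeps a readable antiproliferative effect with only hydrogen on this aromatic carbon, two ring bonds from the ring oxygen, and the 5-chloropent-1-yn-1-yl group is not required for that effect. Compound 2 gives > 100000 nM, which is a limit of the assay and not a number. The removal therefore appears as an at least 1.9-fold lower number from compound 2 to compound 4 (0.28 log units; that floor lies within the scatter), and this is only a floor, so the real size of the change may be larger but cannot be stated, because the starting point is one of the compounds that sit at the limit: the limit of > 100000 nM in this assay, at which 2 of the 4 values shown sit.

The compounds shown leave open whether hydrogen is what matters at this aromatic carbon, or whether a short group such as methyl, an ethynyl group or an amine there would read the same. They also leave open whether the same removal would give a readable number with the hexyl chain of compound 1 in place of the 3-chloropropyl group, or with a carboxylic acid at the end of that chain.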